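Cytotoxicity notes on a macrocyclic thiazole series

The source may report more compounds than this note shows. Statements on the series, on what has been measured and on what is new or still open speak of the compounds shown alone.

Measured so far:
- compound 1, `COc1ccc2c(O[C@H]3C[C@H]4C(=O)N(C)CCCC/C=C/[C@@H]5C[C@@]5(C(=O)NS(=O)(=O)C5(C)CC5)NC(=O)N4C3)cc(-c3nc(C(C)C)cs3)nc2c1Cl`: 48500 nM
- compound 2, `COc1ccc2c(O[C@H]3C[C@H]4C(=O)N(C)CCCC/C=C/[C@@H]5C[C@@]5(C(=O)NS(=O)(=O)C5(C)CC5)NC(=O)N4C3)cc(-c3csc(C(F)(F)F)n3)nc2c1Cl`: 59000 nM
- compound 3, `C#Cc1csc(-c2cc(O[C@H]3C[C@H]4C(=O)N(C)CCCC/C=C/[C@@H]5C[C@@]5(C(=O)NS(=O)(=O)C5(C)CC5)NC(=O)N4C3)c3ccc(OC)c(Cl)c3n2)n1`: 17000 nM

In an ADME assay on Huh-7 cells (Homo sapiens) for cytotoxicity, read by colorimetric assay (a lower number here means that less compound is tolerated, a higher number that more compound is tolerated), compound 3 gives the lowest of the three numbers. The step of a 2.9-fold lower number from compound 1 to compound 3 (0.46 log units; beyond the scatter) lies beyond the scatter, as does the step of a 3.5-fold lower number from compound 2 to compound 3 (0.54 log units; beyond the scatter), so compound 3 is the least tolerated of the measured set. The step of a 1.2-fold higher number from compound 1 to compound 2 (0.09 log units; within the scatter) lies within the scatter.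

Compound 4, `COc1ccc2c(O[C@H]3C[C@H]4C(=O)N(C)CCCC/C=C/[C@@H]5C[C@@]5(C(=O)NS(=O)(=O)C5(C)CC5)NC(=O)N4C3)cc(-c3nc(C#N)cs3)nc2c1Cl`, differs from compound 3 by one change: cyano in place of ethynyl on an aromatic carbon. Going by the values given here, no measured step swaps one of these two groups for the other. The two steps that bear on the position, a 2.9-fold lower number from compound 1 to compound 3 (0.46 log units; beyond the scatter) and a 3.5-fold lower number from compound 2 to compound 3 (0.54 log units; beyond the scatter), show that exchanging the group on this aromatic carbon has moved this assay by a modest amount in both cases, and that the ethynyl group sits at the low end. Ethynyl and cyano are of the same size as counted, so a step no larger than those is expected, and its direction is uncertain.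

Compound 4 is therefore estimated to land near compound 3 in this assay, with a step of a 1.3-fold higher number from compound 3 to compound 4 (0.11 log units; within the scatter) that is expected to stay within the scatter. The estimate for compound 4 is 22000 nM, with a range from 9000 nM to 55000 nM.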

Compound 4, half-maximal cytotoxic concentration: 75000 nM
Beside the measured number, compound 4's estimate is 3.4-fold (0.53 log units) below it; measured number outside the range, above it.
By their numbers in this assay, from the lowest: compound 3; then compounds 1, 2 and 4 (each within the scatter of the next).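

Working notes: in this assay, cyano in place of ethynyl, on the aromatic carbon next to the ring nitrogen, gives a 4.4-fold higher number from compound 3 to compound 4 (0.64 log units; beyond the scatter). This separates two groups that match in heavy-atom count and in their single triple bond, and the counted differences are a nitrogen in place of a carbon and the hydrogen-bond acceptor that cyano adds. Going by these compounds alone, with a 1.5-fold higher number from compound 1 to compound 4 (0.19 log units; within the scatter) and a 1.3-fold higher number from compound 2 to compound 4 (0.10 log units; within the scatter) both within the scatter, compound 3 is now the only compound whose steps to all the others lie beyond the scatter, which sets the ethynyl compound apart from the other three, and no supporting data are available to account for that separation.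

Open, from the compounds shown here alone, is whether a longer chain such as propynyl, or an amine or a carboxylic acid on this carbon, would fall with compound 3 or with the other three. Within the data shown here, also open is whether the gap between ethynyl and cyano would persist on a core other than the one shared by these compounds.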